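A few compounds are considered here, and "the series" means these few. Any claim that something is new, unique, unknown or untested is made for them only; others in the source may bear on it.

Compound 1 (`O=C(Nc1ccc2[nH]c(=O)[nH]c2c1)[C@H]1CCCN1C(=O)C1(c2cccc(Cl)c2)CCCC1`) with 4.4
Compound 2 (`O=C(Nc1cnc2[nH]ncc2c1)[C@H]1CCCN1C(=O)C1(c2cccc(Cl)c2)CCCC1`) with 4.9

Among the measured compounds shown here, in a physicochemical assay for lipophilicity, at pH 7.4 (on this read-out lower numbers stand for lower lipophilicity and higher numbers for higher lipophilicity), compound 2 holds the higher of the two numbers so far, at 4.9, while compound 1 gives 4.4. Compound 3 (`O=C(Nc1ccc2[nH]ncc2c1)[C@H]1CCCN1C(=O)C1(c2cccc(Cl)c2)CCCC1`) has not yet been measured. Its structure departs from that of compound 2 in one place: a group of 9 heavy atoms (7 carbon, 2 nitrogen; one five-membered aromatic ring with 2 hetero atoms, one six-membered aromatic ring of carbon only) in place of a group of 9 heavy atoms (6 carbon, 3 nitrogen; one five-membered aromatic ring with 2 hetero atoms, one six-membered aromatic ring with 1 hetero atom), on an amide-type nitrogen. The incoming group is 1H-indazol-5-yl, and it sits on an amide-type nitrogen whose other neighbour is the carbonyl carbon.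

For the measured compounds named here, only one measured step bears on this change, and it falls at the same place: a number 0.50 log units higher from compound 1 to compound 2 (beyond the scatter). That step is an imperfect guide, as it exchanges a group of a different size and composition. Going by the values given here, no measured pair isolates the present exchange, so the direction remains uncertain. Still, the size of the step from compound 1 suggests a modest move, and a rise seems more likely than a fall. The expected change is a number 0.40 log units higher from compound 2 to compound 3 (beyond the scatter). The estimated value for compound 3 is 5.3, with an expected range from 4.9 to 5.7.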

Compound 3, distribution coefficient: 5.4
Compound 3: middle estimate off by 0.10 log units, on the low side; the range from low to high includes it.
By their numbers in this assay, from the lowest: compound 1; then compound 2; then compound 3.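

In this assay, putting 1H-indazol-5-yl on the amide-type nitrogen in place of the group in compound 2 gives a number 0.50 log units higher from compound 2 to compound 3 (beyond the scatter). Among the compounds shown here, this is the first measured exchange at this position in which the heavy-atom count stays the same, and the two groups differ in that a nitrogen of the six-membered aromatic ring gives way to carbon, with one hydrogen-bond acceptor fewer, so a change of composition alone moves the read-out beyond the scatter. Set against the oxygen-bearing group of compound 1, the same incoming group gives a number 1.00 log units higher from compound 1 to compound 3 (beyond the scatter), so the three groups at this one place now form an order in which each step is beyond the scatter, though no measurement given here explains that order.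

The compounds shown leave open how a carboxylic acid or a primary amine on the group at this nitrogen would read in this assay. They also leave open whether the same order would hold if the 3-chlorophenyl-bearing part of the shared core were exchanged for another group, such as a methoxyphenyl.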